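Removing a methoxy group from a bis-indolyl quinone

A few compounds are considered here, and "the series" means these few. Any claim that something is new, unique, unknown or untested is made for them only; others in the source may bear on it.

- Compound 1 `Cc1[nH]c2ccccc2c1C1=C(Cl)C(=O)C(Cl)=C(c2c(-c3ccccc3)[nH]c3ccccc23)C1=O`: 2.58 ug/mL
- Compound 2 `COc1ccc2[nH]c(C)c(C3=C(Cl)C(=O)C(Cl)=C(c4c(-c5ccc(C)cc5)[nH]c5ccccc45)C3=O)c2c1`: 2.31 ug/mL

Of the compounds shown here, two built on the same shared core have been tested in a functional assay on MCF7 cells (Homo sapiens) for antiproliferative activity, read by CCK-8 assay, with a stated time of 48 h; on this read-out higher numbers stand for weaker inhibition and lower numbers for stronger inhibition. Compound 1 `Cc1[nH]c2ccccc2c1C1=C(Cl)C(=O)C(Cl)=C(c2c(-c3ccccc3)[nH]c3ccccc23)C1=O` gives 2.58 ug/mL, and compound 2 `COc1ccc2[nH]c(C)c(C3=C(Cl)C(=O)C(Cl)=C(c4c(-c5ccc(C)cc5)[nH]c5ccccc45)C3=O)c2c1` gives 2.31 ug/mL. The two numbers sit so close together that the gap between them falls within the usual scatter of this kind of measurement, so neither compound can be called more active than the other.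

Compound 3 `Cc1ccc(-c2[nH]c3ccccc3c2C2=C(Cl)C(=O)C(Cl)=C(c3c(C)[nH]c4ccccc34)C2=O)cc1` is the next compound in the series. It differs from compound 2 in one place: hydrogen in place of methoxy on an aromatic carbon, so that the 5-methoxy-2-methyl-1H-indol-3-yl group becomes a 2-methyl-1H-indol-3-yl group. Going by the values given here, no measured pair shows this exact change. Because compound 1 gives 2.58 ug/mL and compound 2 gives 2.31 ug/mL, values that are nearly the same, the expectation is that the step of a 1.1-fold higher number from compound 2 to compound 3 (0.03 log units; within the scatter) stays within the scatter. Compound 3 is estimated to give 2.5 ug/mL, within a range from 1.2 ug/mL to 5 ug/mL.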

Compound 3, half-maximal inhibitory concentration: 2.88 ug/mL
Compound 3: the middle estimate sits 1.2-fold (0.06 log units) below what was measured, within the range that was stated.
By their numbers in this assay, from the lowest: compounds 2, 1 and 3 (each within the scatter of the next).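

Replacing methoxy with hydrogen on this aromatic carbon gives a 1.2-fold higher number from compound 2 to compound 3 (0.10 log units; within the scatter) in this assay, so these compounds do not separate the two groups at this position. The other single change that can now be read, methyl in place of hydrogen on an aromatic carbon, gives a 1.1-fold higher number from compound 1 to compound 3 (0.05 log units; within the scatter), so that pair does not separate those two groups either. No measurement offered here accounts for either result.

From the compounds shown here alone, it remains open whether a different group on the same aromatic carbon, such as an amine, a carboxylic acid or a longer chain like butoxy, would move the number beyond the scatter. Going by these compounds, it is also open whether methoxy and hydrogen would stay this close if the rest of the molecule were different.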